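From isopropyl to propyl on compound 3

The compounds below may be only part of what the source reports. "The series", "measured", "known", "first", "only" and "open" are said of these compounds alone.

In a physicochemical assay for solubility, read by spectrophotometry, in phosphate buffer, with a stated time of 18 h, at pH 7.4 (a higher number here means a more soluble compound, a lower number a less soluble compound), compound 3 (`Cc1nn(-c2ccccc2)c2nc(-c3ccc(C(C)C)cc3)c(C#N)c(-c3ccccc3O)c12`) gives 9800 nM and stands second of three in this small set, behind compound 2 (`Cc1ccccc1-c1nc2c(c(C)nn2-c2ccccc2)c(-c2ccccc2O)c1C#N`) and ahead of compound 1 (`CCc1ccc(-c2nc3c(c(C)nn3-c3ccccc3)c(-c3ccccc3O)c2C#N)cc1`). Compound 2 gives 21000 nM, and compound 1 gives 3100 nM. Compound 4 (`CCCc1ccc(-c2nc3c(c(C)nn3-c3ccccc3)c(-c3ccccc3O)c2C#N)cc1`) carries propyl in place of isopropyl on an aromatic carbon with the same atoms, joined differently. Going by the values given here, no measured compound carries propyl. The closest guide is compound 1, whose 4-ethylphenyl is also unbranched: a 3.2-fold higher number from compound 1 to compound 3 (0.50 log units; beyond the scatter) is a modest step, and a 2.1-fold lower number from compound 2 to compound 3 (0.33 log units; beyond the scatter) is modest too. A modest fall towards compound 1 is therefore expected. The expected step is a 2.2-fold lower number from compound 3 to compound 4 (0.34 log units; beyond the scatter) by this estimate. Compound 4 is estimated at 4500 nM (range 1800 nM to 11000 nM).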

Compound 4, solubility: 6500 nM
Estimate against measurement, compound 4: 1.4-fold (0.16 log units) below, within the range that was stated.
By their numbers in this assay, from the lowest: compound 1; then compounds 4 and 3 (each within the scatter of the next); then compound 2.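

In this assay, moving from isopropyl to propyl, the same atoms joined differently, gives a 1.5-fold lower number from compound 3 to compound 4 (0.18 log units; within the scatter), so the two chains cannot be told apart at this position. Adding a methyl to the ethyl chain gives a 2.1-fold higher number from compound 1 to compound 4 (0.32 log units; beyond the scatter), while the change of aryl group gives a 3.2-fold lower number from compound 2 to compound 4 (0.51 log units; beyond the scatter), so compound 4 sits clear of both neighbours. Nothing measured here explains these differences.

Still open, going by these compounds, is whether a longer chain such as butyl would continue the step up from ethyl. On these data alone, an amine or a carboxylic acid in the same place also remains untested by these compounds.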